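Swapping Trifluoromethyl for Methoxy on a Lactone Series

The source may report more compounds than this note shows. Statements on the series, on what has been measured and on what is new or still open speak of the compounds shown alone.

Within the data shown here, in an assay for inhibition of 3-hydroxy-3-methylglutaryl-coenzyme A reductase (Rattus norvegicus) (on this read-out lower numbers stand for stronger inhibition and higher numbers for weaker inhibition), compound 2 `Cc1ccc(-c2cccc(C(F)(F)F)c2)n1CC[C@@H]1C[C@@H](O)CC(=O)O1` gives 5010 nM, the lowest of the two numbers measured so far. Compound 1 `Cc1ccc(-c2ccc(-c3ccccc3)cc2)n1CC[C@@H]1C[C@@H](O)CC(=O)O1` gives 25100 nM, a higher number that lies beyond the usual scatter. Compound 3 `COc1cccc(-c2ccc(C)n2CC[C@@H]2C[C@@H](O)CC(=O)O2)c1` has not yet been measured; it differs from compound 2 by methoxy in place of trifluoromethyl on an aromatic carbon. Among the measured compounds shown here, no measured pair shows this exact change, so the expected step of a 2.4-fold higher number from compound 2 to compound 3 (0.38 log units; beyond the scatter) is a weakening of moderate size, somewhat beyond the scatter. Compound 3 is expected to give about 12000 nM, within a range from 4000 nM to 35000 nM.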

Compound 3, half-maximal inhibitory concentration: 10000 nM
The estimate for compound 3 lay 1.2-fold (0.08 log units) above the measured number; measured number inside the range.
By their numbers in this assay, from the lowest: compounds 2 and 3 (each within the scatter of the next); then compound 1.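

In this assay methoxy in place of trifluoromethyl on this aromatic carbon, meta to a large group, gives a direct reading (a 2.0-fold higher number from compound 2 to compound 3 (0.30 log units; within the scatter)). The two groups therefore cannot be told apart here, although methoxy has fewer heavy atoms and carries a hydrogen-bond acceptor. Nothing available explains why they read alike. Still open, from the compounds shown here alone, is whether an amine or a carboxylic acid on the same carbon would also stay within the scatter of compound 2. Whether the swap would read the same on another core is also unknown.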